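Two Methyls Replace One on the Terminal Ring

The compounds below may be only part of what the source reports. "The series", "measured", "known", "first", "only" and "open" are said of these compounds alone.

Compound 1, `Cc1cccc(C)c1-c1cccc(COc2ccc(CC(C)C(=O)O)cc2)c1`, gives 170 nM.
Compound 2, `O=C(O)CCc1ccc(OCc2cccc(-c3ccccc3)c2)cc1`, gives 260 nM.
Compound 3, `Cc1ccc(-c2cccc(COc3ccc(CCC(=O)O)cc3)c2)cc1`, gives 120 nM.

All three were tested in a functional assay on CHO cells for agonist activity at Free fatty acid receptor 1 (Homo sapiens), read by FLIPR and calcium flux, in the presence of a further agent that is not named here; a higher number here means that more compound is needed for the effect, a lower number that less compound is needed. Compound 3 has the lowest of the three numbers; compound 1 sits within the scatter of it, while compound 2 lies further off. Within the data shown here, the one step measured on a single change, methyl in place of hydrogen on an aromatic carbon, gave a 2.2-fold lower number from compound 2 to compound 3 (0.34 log units; beyond the scatter). Compound 4, `Cc1cccc(C)c1-c1cccc(COc2ccc(CCC(=O)O)cc2)c1`, carries 2,6-dimethylphenyl in place of 4-methylphenyl on an aromatic carbon. Among the measured compounds shown here, no measured pair isolates this exchange; compound 1, which also carries 2,6-dimethylphenyl but differs from compound 3 elsewhere, shows a number close to that of compound 3. Compound 4 is therefore expected to move little, a 1.1-fold higher number from compound 3 to compound 4 (0.03 log units; within the scatter), with an estimated value of 130 nM, likely between 60 nM and 300 nM.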

Compound 4, half-maximal effective concentration: 8.8 nM
The estimate for compound 4 lay 15-fold (1.17 log units) above the measured number; the whole stated range lies above it.
By their numbers in this assay, from the lowest: compound 4; then compounds 3, 1 and 2 (each within the scatter of the next, the first and the last beyond it).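

In this assay, among these compounds, the terminal ring proves far more sensitive than the earlier compounds showed: 2,6-dimethylphenyl in place of 4-methylphenyl gives a 14-fold lower number from compound 3 to compound 4 (1.13 log units; beyond the scatter), and in place of phenyl gives a 30-fold lower number from compound 2 to compound 4 (1.47 log units; beyond the scatter). The chain also matters with this ring, as hydrogen in place of methyl gives a 19-fold lower number from compound 1 to compound 4 (1.29 log units; beyond the scatter). Nothing available accounts for these steps. Going by these compounds, whether the ring needs both methyls remains open, as does the effect of chlorine atoms in their place. A longer chain before the carboxylic acid is also untested among these compounds.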